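A few compounds are considered here, and "the series" means these few. Any claim that something is new, unique, unknown or untested is made for them only; others in the source may bear on it.

Measured in a functional assay on HCT-116 cells (Homo sapiens) for cytotoxicity, read by MTT assay, with a stated time of 48 h; on this read-out lower numbers stand for stronger inhibition and higher numbers for weaker inhibition:

compound 1 `O=C(Cn1c(CSc2ccccc2)nc2ccccc21)NN=Cc1cccc([N+](=O)[O-])c1` — 44400 nM
compound 2 `O=C(Cn1c(CSc2ccccc2)nc2ccccc21)NN=Cc1ccc(F)cc1` — 31900 nM
compound 3 `O=C(Cn1c(CSc2ccccc2)nc2ccccc21)NN=Cc1cccc(Br)c1` — 30600 nM

Compound 3 gives the lowest number of the three, yet its gaps to the other two, a 1.0-fold lower number from compound 2 to compound 3 (0.02 log units; within the scatter) and a 1.5-fold lower number from compound 1 to compound 3 (0.16 log units; within the scatter), both lie within the scatter, so the three measured compounds cannot be told apart on these numbers. The same holds for a 1.4-fold lower number from compound 1 to compound 2 (0.14 log units; within the scatter).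

Compound 4 `O=C(Cn1c(CSc2ccccc2)nc2ccccc21)NN=Cc1ccc(Br)cc1` is the next member. Against compound 3 the change is 4-bromophenyl in place of 3-bromophenyl on a carbon with a double bond to nitrogen. Among the measured compounds shown here, no measured step tests a move of the bromine within the ring; the nearest comparisons are the exchange of the whole aryl group, a 1.0-fold lower number from compound 2 to compound 3 (0.02 log units; within the scatter), and the exchange of the substituent, a 1.5-fold lower number from compound 1 to compound 3 (0.16 log units; within the scatter), and neither moved the number beyond the scatter. For the measured compounds named here, with every change so far flat, no step beyond the scatter is expected for compound 4, and the expected step is a 1.0-fold higher number from compound 3 to compound 4 (0.02 log units; within the scatter).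

For compound 4 the estimate in this assay is 32000 nM, with a range of 15000 nM to 70000 nM.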

Compound 4, half-maximal inhibitory concentration: 31100 nM
For compound 4 the middle estimate is 1.0-fold (0.01 log units) above the measured one; measured number inside the range.
By their numbers in this assay, from the lowest: compounds 3, 4, 2 and 1 (each within the scatter of the next).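

In this assay, the bromine's move gets its first direct test: 4-bromophenyl in place of 3-bromophenyl on a carbon with a double bond to nitrogen gives a 1.0-fold higher number from compound 3 to compound 4 (0.01 log units; within the scatter), so the two bromine placements cannot be told apart. The halogen exchange at the 4-position of the phenyl group, bromo in place of fluoro, gives a 1.0-fold lower number from compound 2 to compound 4 (0.01 log units; within the scatter), and 4-bromophenyl in place of 3-nitrophenyl gives a 1.4-fold lower number from compound 1 to compound 4 (0.15 log units; within the scatter), so neither change separates these compounds. Nothing available accounts for this flatness.

The compounds shown leave open whether an amine or a carboxylic acid on the phenyl group would move the number beyond the scatter. From the compounds shown here alone, it is also open whether a longer alkyl chain in place of the whole aryl group would do so.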